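The source may hold more compounds than are shown below. What is called first, only, known or untested is meant among the compounds shown, and "the series" means these compounds.

Working notes on the shared core. In a functional assay on CHO cells for agonist activity at Melanocortin receptor 4 (Homo sapiens), read by a luciferase reporter, with a stated time of 4 h (a higher number here means that more compound is needed for the effect, a lower number that less compound is needed), compound 1 `CC(C)N(C(=O)CN1C=CN(c2ccccc2)C(=O)C(Cc2n[nH]c3ccccc23)C1=O)c1ccc(F)cc1` gives 282 nM. Among the measured compounds shown here, compound 2 `CC(C)N(C(=O)CN1C=CN(c2ccccc2)C(=O)[C@H](Cc2n[nH]c3ccccc23)C1=O)c1ccccc1`, the one member drawn with a set configuration at the saturated ring carbon, gives 1070 nM in this assay, the higher of the two single numbers; the gap to compound 1 lies beyond the scatter. Compound 3 `CC(C)N(C(=O)CN1C=CN(c2ccccc2)C(=O)C(Cc2n[nH]c3ccccc23)C1=O)c1ccc(O)cc1` gives 1000 nM; 1000 nM; 31600 nM; > 30000 nM (4 entries) in this assay. Two of these entries of compound 3 are limits of the assay and not numbers. Compound 4 `CC(C)N(C(=O)CN1C=CN(c2ccccc2)C(=O)C(Cc2n[nH]c3ccccc23)C1=O)c1ccccc1` awaits measurement; the change the two compounds have the same atoms and bonds; at least one stereo element is drawn with a configuration in one of them and without one in the other: 1 of 1 stereo elements differ; a stereocentre at a saturated ring carbon is drawn R in compound 2 and without a configuration in compound 4 alters no atom or bond. For the measured compounds named here, no measured step of this kind exists here, so the expected step from compound 2 to compound 4 is a 1.2-fold lower number from compound 2 to compound 4 (0.08 log units; within the scatter), small and within the scatter. Compound 4 is therefore estimated at 900 nM, range 250 nM to 3500 nM.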

Compound 4, half-maximal effective concentration: 3240 nM
Compound 4: middle estimate off by 3.6-fold (0.56 log units), on the low side, within the range that was stated.
By their numbers in this assay, from the lowest: compound 1; then compound 2; then compound 4.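

The step at the saturated ring carbon alters no atom or bond, yet in this assay it gives a 3.0-fold higher number from compound 2 to compound 4 (0.48 log units; beyond the scatter). Among the compounds shown here, the only difference behind that step is this: the fact that one of compounds 2 and 4 is drawn with a defined configuration and the other without, at the place where they differ. With both compounds drawn without a configuration at that carbon, hydrogen in place of fluoro on an aromatic carbon gives an 11-fold higher number from compound 1 to compound 4 (1.06 log units; beyond the scatter), so this aromatic position also moves the number.

The compounds shown leave open how the opposite configuration at the ring carbon reads. They also leave open whether chloro or methoxy on that aromatic carbon would follow fluoro.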